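The source may report more compounds than this note shows. Statements on the series, on what has been measured and on what is new or still open speak of the compounds shown alone.

Compound 1 `CC1(/C=C/c2ccccc2C(F)(F)F)C=CC(=O)O1`: 12200 nM
Compound 2 `COc1c(O)ccc(/C=C/C2(C)C=CC(=O)O2)c1OC`: 51600 nM

Both compounds were tested in a functional assay on NCI/ADR-RES cells (Homo sapiens) for inhibition, read by sulforhodamine B assay, with a stated time of 48 h (on this read-out higher numbers stand for weaker inhibition of growth and lower numbers for stronger inhibition of growth), and differ clearly. Compound 1 holds the lower of the two numbers at 12200 nM and compound 2 reads higher at 51600 nM, a gap beyond the usual scatter.

Compound 3 `COc1ccccc1/C=C/C1(C)C=CC(=O)O1` has not yet been measured in this assay. It departs from compound 1 in one place, with methoxy in place of trifluoromethyl on an aromatic carbon, ortho to a group of 9 heavy atoms (methoxy in place of trifluoromethyl on an aromatic carbon).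

For the measured compounds named here, no measured pair shows this exchange on its own, so any expectation rests on thin ground. Compound 2 also bears methoxy and gives 51600 nM in this assay, which points to a moderate rise in the number for compound 3, toward weaker inhibition of growth, though one that may not clear the scatter by much. The expected change is a 2.0-fold higher number from compound 1 to compound 3 (0.29 log units; within the scatter) on this evidence. In this assay the estimate for compound 3 is 24000 nM and the expected range runs from 10000 nM to 58000 nM at this stage.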

Compound 3, concentration for total growth inhibition: 64500 nM
Estimate against measurement, compound 3: 2.7-fold (0.43 log units) below; measured number above the stated range.
By their numbers in this assay, from the lowest: compound 1; then compounds 2 and 3 (each within the scatter of the next).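

In this assay, for the compounds shown here, the exchange of trifluoromethyl for methoxy on an aromatic carbon, ortho to a group of 9 heavy atoms, gives a 5.3-fold higher number from compound 1 to compound 3 (0.72 log units; beyond the scatter) and so provides the first direct reading of this change on the shared core. It shows that the group at this place matters for the read-out, with the step running toward weaker inhibition of growth when methoxy replaces trifluoromethyl. No measurement shown here accounts for the size or direction of this step.

Going by these compounds alone, the single pair leaves open whether the step reflects something gained with methoxy or something lost with trifluoromethyl, and a plain hydrogen, a chlorine atom or a nitrile at the same place would help to separate the two. It also leaves open whether the same exchange would give a step of similar size on another aromatic carbon of the ring, or on a core carrying further groups.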